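The source may hold more compounds than are shown below. What is called first, only, known or untested is meant among the compounds shown, and "the series" means these compounds.

In a functional assay on CCRF-CEM cells (Homo sapiens) for cytotoxicity, read by XTT assay, with a stated time of 3 days (a higher number here means a weaker inhibitor, a lower number a stronger inhibitor), compound 1 `OC[C@H]1O[C@@H](n2cc(F)c3c(-c4ccccc4)ncnc32)[C@H](O)[C@@H]1O` gives 3100 nM and compound 2 `OC[C@H]1O[C@@H](n2cc(F)c3c(-c4ccc[nH]4)ncnc32)[C@H](O)[C@@H]1O` gives 410 nM as the lower number of the two, which marks the stronger inhibitor. Compound 3 `OC[C@H]1O[C@@H](n2cc(F)c3c(-c4c[nH]cn4)ncnc32)[C@H](O)[C@@H]1O` differs from compound 2 as follows: 1H-imidazol-4-yl in place of 1H-pyrrol-2-yl on an aromatic carbon with 1H-imidazol-4-yl in place of 1H-pyrrol-2-yl on an aromatic carbon. Among the measured compounds shown here, the only measured step at this place is a 7.6-fold lower number from compound 1 to compound 2 (0.88 log units; beyond the scatter) and it is modest, with 1H-pyrrol-2-yl replacing phenyl. For the measured compounds named here, no measured compound carries 1H-imidazol-4-yl, so the direction is uncertain. The expected step is a 2.7-fold higher number from compound 2 to compound 3 (0.43 log units; beyond the scatter) and it is of similar modest size, towards a higher number. Compound 3 is estimated at 1100 nM with an expected range from 250 nM to 5500 nM at its upper end.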

Compound 3, half-maximal inhibitory concentration: 1800 nM
Beside the measured number, compound 3's estimate is 1.6-fold (0.21 log units) below it; the measured number falls inside the stated range.
By their numbers in this assay, from the lowest: compound 2; then compounds 3 and 1 (each within the scatter of the next).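

In this assay, 1H-imidazol-4-yl in place of 1H-pyrrol-2-yl gives a 4.4-fold higher number from compound 2 to compound 3 (0.64 log units; beyond the scatter) and so loses much of the gain seen with 1H-pyrrol-2-yl, showing that this position distinguishes between two five-membered aromatic rings that each carry a hydrogen-bond donor. Against phenyl, 1H-imidazol-4-yl gives a 1.7-fold lower number from compound 1 to compound 3 (0.24 log units; within the scatter) and so shows no real change. No measurement here explains why the second ring nitrogen matters.

Still open, on these data alone, is whether the pyrrole's advantage survives when it carries a methyl or an amine. A carboxylic acid at this position also remains untested among the compounds shown.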